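The source may hold more compounds than are shown below. What is called first, only, known or untested is meant among the compounds shown, and "the series" means these compounds.

Compound 1 `N#Cc1ccc(Nc2nccc(OCc3ccccc3F)n2)cc1`: 151000 nM
Compound 2 `N#Cc1ccc(Nc2nccc(OCc3cccc(F)c3)n2)cc1`: 105000 nM

In an ADME assay on MT4 cells (Homo sapiens) for cytotoxicity, read by MTT assay, with a stated time of 5 days (on this read-out higher numbers stand for lower toxicity in this test and lower numbers for higher toxicity in this test), compound 2 gives 105000 nM, which lies within the scatter of the number for compound 1, so the two cannot be told apart on this read-out. Compound 3 `N#Cc1ccc(Nc2nccc(OCc3ccc(F)cc3)n2)cc1` keeps the shared core and changes only the fluorinated ring: 4-fluorophenyl in place of 3-fluorophenyl on a saturated chain carbon bound to an oxygen on an aromatic ring. Among the measured compounds shown here, only one measured step bears on this change. It falls at the same place and also moves the fluorine around the ring, and it is a 1.4-fold lower number from compound 1 to compound 2 (0.16 log units; within the scatter). For the measured compounds named here, with only this step as a guide, nothing in the data points to a real shift in either direction for the 4-fluorophenyl group, so no change beyond the scatter is expected in this assay. The estimated step is a 1.1-fold higher number from compound 2 to compound 3 (0.06 log units; within the scatter). For compound 3 the expected value is 120000 nM, with an estimated range from 65000 nM to 220000 nM.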

Compound 3, half-maximal cytotoxic concentration: 81000 nM
Compound 3: the middle estimate sits 1.5-fold (0.17 log units) above what was measured, and the stated range covers the measured number.
By their numbers in this assay, from the lowest: compounds 3, 2 and 1 (each within the scatter of the next).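

With compound 3, all three fluorophenyl groups at this place have a number in this assay, and both new steps stay within the scatter: a 1.3-fold lower number from compound 2 to compound 3 (0.11 log units; within the scatter) and a 1.9-fold lower number from compound 1 to compound 3 (0.27 log units; within the scatter). Moving the fluorine around the ring, on a saturated chain carbon bound to an oxygen on an aromatic ring, therefore gives no difference this read-out can separate among these three compounds, even between the 2-fluorophenyl and 4-fluorophenyl groups. Nothing available here offers an explanation for these numbers.

The compounds shown leave open whether a group of another kind at this place, such as an amine, a carboxylic acid or a longer chain, would move the number beyond the scatter. They also leave open how an unsubstituted phenyl or a chlorophenyl group would compare with these fluorophenyl groups.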